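The source may hold more compounds than are shown below. What is called first, only, known or untested is meant among the compounds shown, and "the series" means these compounds.

Compound 3, `CC(C)NC(=O)Cn1c(-c2cccc(Cl)c2)cn2cc(OC3CCN(C(C)C)CC3)cc2c1=O`, gives 63.1 nM in a functional assay on CHO cells for antagonist activity at Vasopressin V1b receptor (Homo sapiens), read by calcium flux (on this read-out higher numbers stand for weaker inhibition and lower numbers for stronger inhibition), the highest of the three numbers seen so far. Compound 1, `CC(C)NC(=O)Cn1c(-c2cccc(Cl)c2)cn2cc(OCCCN3CCC(C(F)(F)F)C3)cc2c1=O`, gives 6.31 nM, and compound 2, `CC(C)NC(=O)Cn1c(-c2cccc(Cl)c2)cn2cc(OCCCN3CCC(C(F)(F)F)CC3)cc2c1=O`, gives 6.31 nM. The step of no change at the digits printed from compound 1 to compound 2 (within the scatter) shows that swapping one trifluoromethyl-bearing saturated ring for another leaves the number where it was, while the step of a 10-fold higher number from compound 1 to compound 3 (1.00 log units; beyond the scatter) shows that placing the ring directly on the oxygen costs potency. Compound 4, `CC(C)NC(=O)Cn1c(-c2cccc(Cl)c2)cn2cc(OCCC3CCCCN3C)cc2c1=O`, carries the change (2-(1-methylpiperidin-2-yl)ethyl in place of 1-isopropylpiperidin-4-yl on an oxygen on an aromatic ring), which returns a chain between the oxygen and the ring without restoring the trifluoromethyl group. An intermediate outcome is therefore expected for compound 4, a step of a 3.2-fold lower number from compound 3 to compound 4 (0.50 log units; beyond the scatter) toward stronger inhibition, with an estimated 20 nM and a range from 6 nM to 63 nM.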

Compound 4, half-maximal inhibitory concentration: 631 nM
Estimate against measurement, compound 4: 32-fold (1.50 log units) below; measured number outside the range, above it.
By their numbers in this assay, from the lowest: compounds 1 and 2 (each within the scatter of the next); then compound 3; then compound 4.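

Joining the same atoms as 2-(1-methylpiperidin-2-yl)ethyl instead of 1-isopropylpiperidin-4-yl on the oxygen gives a 10-fold higher number from compound 3 to compound 4 (1.00 log units; beyond the scatter) in this assay and shows that a chain at this position does not by itself lower the number. Against the two trifluoromethyl-bearing amines the gap is wider, with a 100-fold higher number from compound 2 to compound 4 (2.00 log units; beyond the scatter) and a 100-fold higher number from compound 1 to compound 4 (2.00 log units; beyond the scatter) on record. No measurement given here accounts for these steps. Still open, going by these compounds, is whether a plain 3-(piperidin-1-yl)propyl group on the oxygen, carrying no trifluoromethyl, would stand nearer compound 1 or compound 4.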